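The compounds below may be only part of what the source reports. "The series", "measured", "known", "first", "only" and "open" are said of these compounds alone.

Of the compounds shown here, two have been measured. In an assay on Sf9 cells for inhibition of protein deacetylase HDAC6 (Homo sapiens), read by fluorescence, with a stated time of 40 min (on this read-out lower numbers stand for stronger inhibition and higher numbers for weaker inhibition), compound 1 `O=C(NO)c1ccc(NCc2nc(-c3ccc(Cl)cc3)nn2-c2ccccc2)cc1` gives 181 nM, and compound 2 `Cc1ccc(-c2nc(CNc3ccc(C(=O)NO)cc3)n(-c3ccccc3)n2)s1` gives 30.6 nM, the lowest of the two numbers. Going by the values given here, the one step so far, a 5.9-fold lower number from compound 1 to compound 2 (0.77 log units; beyond the scatter), exchanged the aryl group on the shared core. Compound 3 `Cc1cccc(-c2nc(CNc3ccc(C(=O)NO)cc3)n(-c3ccccc3)n2)c1` is the next member: 3-methylphenyl in place of 5-methylthiophen-2-yl on an aromatic carbon. Among the compounds with values here, no measured step bears directly on this exchange; the six-membered ring carries compound 3 back toward compound 1, whose number stands above that of compound 2. A modest rise is therefore expected, a 2.6-fold higher number from compound 2 to compound 3 (0.42 log units; beyond the scatter). Compound 3 is estimated at 80 nM, within 25 nM to 250 nM.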

Compound 3, half-maximal inhibitory concentration: 281 nM
The estimate for compound 3 lay 3.5-fold (0.55 log units) below the measured number; measured number above the stated range.
By their numbers in this assay, from the lowest: compound 2; then compounds 1 and 3 (each within the scatter of the next).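

In this assay the change at this ring carbon is large: 3-methylphenyl in place of 5-methylthiophen-2-yl gives a 9.2-fold higher number from compound 2 to compound 3 (0.96 log units; beyond the scatter) and so the low number of compound 2 stays alone in the series. The two six-membered aryl groups do not separate, with a 1.6-fold higher number from compound 1 to compound 3 (0.19 log units; within the scatter) and so 3-methylphenyl and 4-chlorophenyl cannot be ranked. No measurement on hand accounts for the gap. As far as these compounds go, whether the low number of compound 2 goes with the sulfur-containing ring or with its methyl group stays open. An unsubstituted thiophen-2-yl or a furan-2-yl at this carbon would bear on that.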